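Replacing bromo with dimethyl-isoxazolyl on a diaryl ether scaffold

A few compounds are considered here, and "the series" means these few. Any claim that something is new, unique, unknown or untested is made for them only; others in the source may bear on it.

Measured compounds:
Compound 1 `Cn1cc(-c2cc(NS(C)(=O)=O)ccc2Oc2cccc(Br)c2)n2cncc2c1=O` gives 450 nM in a functional assay on HL-60 cells (Homo sapiens) for antiproliferative activity, read by MTT assay; on this read-out higher numbers stand for weaker inhibition and lower numbers for stronger inhibition.
Compound 2 `CCS(=O)(=O)Nc1ccc(Oc2ccc(F)cc2)c(-c2cn(C)c(=O)c3cncn23)c1` gives 45 nM in this assay.

Compound 1 stands at the highest of the two numbers in this assay; its nearest neighbour is compound 2, whose number is lower by a margin that lies beyond the usual scatter. Going by the values given here, compound 2 differs from compound 1 in several places at once, so no single step between the two can be read out.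

Compound 3 `Cc1noc(C)c1-c1cccc(Oc2ccc(NS(C)(=O)=O)cc2-c2cn(C)c(=O)c3cncn23)c1` has not yet been measured. It differs from compound 1 in one place: 3,5-dimethyl-1,2-oxazol-4-yl in place of bromo on an aromatic carbon, on an aromatic carbon of a six-membered aromatic ring of carbon only, meta to a large group. Among the compounds with values here, no measured pair shows this change. The step is expected to be small, probably a modest move towards a lower number, and it may not exceed the scatter; the expected step is a 1.8-fold lower number from compound 1 to compound 3 (0.26 log units; within the scatter). For compound 3 the estimate in this assay is 250 nM, within a range of 60 nM to 1000 nM.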

Compound 3, half-maximal inhibitory concentration: 1230 nM
For compound 3 the middle estimate is 4.9-fold (0.69 log units) below the measured one, outside the stated range (above it).
By their numbers in this assay, from the lowest: compound 2; then compound 1; then compound 3.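

In this assay, going by these compounds alone, the exchange of bromo for 3,5-dimethyl-1,2-oxazol-4-yl gives the first reading of a single change at this aromatic carbon, meta to a large group (a 2.7-fold higher number from compound 1 to compound 3 (0.44 log units; beyond the scatter)). The step is modest but beyond the usual scatter, and it points towards weaker inhibition, so this change loses antiproliferative activity rather than gaining it, although activity remains measurable with the larger five-membered aromatic ring in place. Nothing measured here accounts for the loss.

It remains open whether the loss comes from the ring itself or from its two methyl groups, since an unsubstituted 1,2-oxazol-4-yl does not appear among these compounds. As far as these compounds go, how a smaller group at this place, such as methoxy or an amine, or a carboxylic acid would compare with bromo also stays unknown.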